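Sulfonyl substituent swaps: compound 3 to compound 4

This account rests on a few compounds, and the source may have more. Where it says the series, first, only, none or still open, it means among the compounds named here.

In a functional assay on A549 cells (Homo sapiens) for antiproliferative activity, read by MTT assay, with a stated time of 48 h (on this read-out lower numbers stand for stronger inhibition and higher numbers for weaker inhibition), compound 1 `Cn1cc(-c2cnc3ccc(NS(=O)(=O)c4ccc(C(F)(F)F)cc4)nc3c2)cn1` returns only a limit, > 50000 nM, and not a number. Compound 2 `Cc1ccc(S(=O)(=O)Nc2ccc3ncc(-c4cnn(C)c4)cc3n2)cc1` gives 45500 nM. Compound 3 `Cn1cc(-c2cnc3ccc(NS(=O)(=O)c4cccs4)nc3c2)cn1` gives 39500 nM, which lies within the scatter of compound 2, so neither of the two numbers stands clearly apart.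

The next change leads to compound 4 `Cn1cc(-c2cnc3ccc(NS(=O)(=O)c4ccc(Cl)cc4Cl)nc3c2)cn1`, with 2,4-dichlorophenyl in place of thiophen-2-yl on a sulfonyl sulfur.

Among the compounds with values here, three measured steps bear on this change. The exchange of 4-methylphenyl for thiophen-2-yl on the sulfonyl sulfur gives a 1.2-fold lower number from compound 2 to compound 3 (0.06 log units; within the scatter). The exchange of 4-(trifluoromethyl)phenyl for thiophen-2-yl gives an at least 1.2-fold lower number from compound 1 to compound 3 (0.10 log units; that floor lies within the scatter), and methyl in place of trifluoromethyl gives an at least 1.0-fold lower number from compound 1 to compound 2 (0.04 log units; that floor lies within the scatter). The last two are floors set by a limit, so only the first has a defined size. Within the data shown here, none shows a change beyond the scatter, but no measured compound carries 2,4-dichlorophenyl.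

No step beyond the scatter is therefore expected in this assay, and the expected change is a 1.3-fold lower number from compound 3 to compound 4 (0.12 log units; within the scatter). Compound 4 is estimated at 30000 nM, with an expected range of 8000 nM to 60000 nM. A report of a limit alone would not be surprising.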

Compound 4, half-maximal inhibitory concentration: > 50000 nM
Compound 4 ended at the assay's limit; the forecaster's own chance of this, stated with the estimate: 30%; middle value at least 1.6-fold (0.22 log units) away from the limit.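

In this assay compound 4 returns only a limit, > 50000 nM, and not a number. Replacing thiophen-2-yl or 4-methylphenyl with 2,4-dichlorophenyl on the sulfonyl sulfur gives only floors, an at least 1.2-fold higher number from compound 3 to compound 4 (0.10 log units; that floor lies within the scatter) and an at least 1.0-fold higher number from compound 2 to compound 4 (0.04 log units; that floor lies within the scatter), both within the scatter, and the step between compound 1 and compound 4 cannot be read at all. What is new is that a group with two chlorine atoms on its ring also gives no number clearly lower than those of compound 2 and compound 3, and a second compound now sits at the limit: the limit of > 50000 nM in this assay, at which 2 of the 4 values shown sit.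

The true size of the change from thiophen-2-yl to 2,4-dichlorophenyl stays unknown, since only a floor is available, and all the groups on the sulfonyl sulfur shown so far are aromatic rings. Going by these compounds, whether a non-aromatic group at this place, such as a plain methyl or a short chain ending in an amine or a carboxylic acid, would move the number clearly beyond the scatter remains open.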